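The compounds below may be only part of what the source reports. "The series", "measured", "known", "first", "only" and "open" are said of these compounds alone.

Measured so far:
compound 1 `CNC(=O)c1cc(C(=O)N[C@H]2CC[C@H](O)CC2)c([C@@H](C)c2ccccc2Cl)o1` — >= 242 ug/mL
compound 2 `CNC(=O)c1cc(C(=O)N[C@H]2CC[C@H](O)CC2)n([C@@H](C)c2ccccc2Cl)n1` — >= 182 ug/mL

In a physicochemical assay for solubility, measured as kinetic solubility (a lower number here means a less soluble compound, a higher number a more soluble compound), compound 1 gives >= 242 ug/mL, which is a limit of the assay and not a number, (the limit of >= 242 ug/mL in this assay, at which 1 of the 2 values shown sits). Compound 2 likewise returns only a limit, >= 182 ug/mL, (the limit of >= 182 ug/mL in this assay, at which 1 of the 2 values shown sits). On the numbers shown, compound 1 stands at a limit in this assay and cannot be ranked. Compound 3 `CNC(=O)c1cc(C(=O)N[C@H]2CC[C@H](O)CC2)c([C@@H](C)c2ccc(C)cc2)o1` is not yet measured; it differs from compound 1 by 4-methylphenyl in place of 2-chlorophenyl on a saturated chain carbon bound to an aromatic carbon and a saturated chain carbon. Going by the values given here, no measured step exists for comparison. The expected step of an at least 1.2-fold lower number from compound 1 to compound 3 (0.08 log units; that floor lies within the scatter) is none beyond the scatter, with a fair chance that compound 3 again reports only a limit. Compound 3 is estimated at 200 ug/mL, within 80 ug/mL to 300 ug/mL.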

Compound 3, solubility: >= 245 ug/mL
Compound 3: no number, only a limit (the forecaster's own chance of this, stated with the estimate: 55%); middle value at least 1.2-fold (0.08 log units) from the limit.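

Going by these compounds alone, compound 1 and compound 3 both return only a limit in this assay, and no step between them can be read. The compounds shown leave open whether 4-methylphenyl in place of 2-chlorophenyl shifts this read-out at all.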